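Amide on the ring amine of compound 2

This account rests on a few compounds, and the source may have more. Where it says the series, first, only, none or still open, it means among the compounds named here.

Three members of the series carry a measured number. Compound 1 `CN1Cc2c(N)cccc2C(c2ccc(Cl)cc2)C1` gives 1.5 mg/kg in a functional assay on the whole organism for inhibition of sodium-dependent dopamine transporter (Mus musculus); on this read-out lower numbers stand for an effect already at smaller amounts and higher numbers for an effect only at larger amounts of compound. Compound 2 `Cc1ccc(C2CN(C)Cc3c(N)cccc32)cc1` gives about 22 mg/kg in this assay, and compound 3 `CC(C)c1ccc(C2CN(C)Cc3c(N)cccc32)cc1` gives about 65 mg/kg in this assay. Compound 2 thus stands second highest of the three numbers: a 15-fold higher number from compound 1 to compound 2 (1.17 log units; beyond the scatter), and a 3.0-fold higher number from compound 2 to compound 3 (0.47 log units; beyond the scatter), while a 43-fold higher number from compound 1 to compound 3 (1.64 log units; beyond the scatter) spans the whole set.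

Compound 4 `CCNCC(=O)Nc1cccc2c1CN(C)CC2c1ccc(C)cc1` is the next candidate for this assay. It differs from compound 2 by ((ethylamino)methyl)carbonyl in place of hydrogen on a nitrogen on an aromatic ring. Among the compounds with values here, none of the three measured steps bears on this site: each of them exchanges one group on an aromatic carbon, two of those steps being large and one modest, and no measured pair differs at the ring nitrogen. Within the data shown here, there is therefore no measured step from which a direction can be read for this assay.

With no guidance from the measured steps, the step from compound 2 to compound 4 is expected to be a 1.4-fold higher number from compound 2 to compound 4 (0.13 log units; within the scatter), the default of no shift beyond the scatter, held with a wide margin. For compound 4 the estimated number in this assay is 30 mg/kg, with a range from 8 mg/kg to 110 mg/kg.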

Compound 4, dose for half-maximal effect: about 15 mg/kg
For compound 4 the middle estimate is 2.0-fold (0.30 log units) above the measured one; low and high end bracket the measured number.
By their numbers in this assay, from the lowest: compound 1; then compounds 4 and 2 (each within the scatter of the next); then compound 3.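

In this assay, ((ethylamino)methyl)carbonyl in place of hydrogen on the nitrogen on an aromatic ring gives a 1.5-fold lower number from compound 2 to compound 4 (0.17 log units; within the scatter), so a group of 6 heavy atoms enters at this site with no shift beyond the scatter. Within the data shown here, this is the first reading at this nitrogen, and it contrasts with the exchanges on an aromatic carbon, where even the smallest, a 3.0-fold higher number from compound 2 to compound 3 (0.47 log units; beyond the scatter), lies beyond the scatter. It remains a single pair on a single background, so it supports no general rule for the site, and no measurement at hand accounts for the result.

Open, as far as these compounds go, is whether the same ((ethylamino)methyl)carbonyl on the core of compound 1, which gives 1.5 mg/kg, would also stay within the scatter of its parent, given that the chloro compound sits much lower. Also open, from the compounds shown here alone, is how the nitrogen would respond to a plain acetyl group, a longer chain between the carbonyl and the amine, or a carboxylic acid in place of the terminal ethylamino group.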